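Replacing 2-methylphenyl with 4-aminophenyl on a carbonyl carbon

The source may hold more compounds than are shown below. What is called first, only, known or untested is meant among the compounds shown, and "the series" means these compounds.

In an ADME assay on a cell-free system (serum) for metabolic stability (on this read-out higher numbers stand for a longer-lived compound and lower numbers for a shorter-lived compound), compound 1 `Cc1ccc(C(=O)Oc2ccc(O)c(C(C)(C)C)c2)cc1` gives < 0.25 h as a limit. Compound 2 `Cc1ccccc1C(=O)Oc1ccc(O)c(C(C)(C)C)c1` gives < 0.25 h as a limit too, and so stands at the limit of < 0.25 h in this assay, at which 2 of the 2 values shown sit, with no number of its own. Compound 3 `CC(C)(C)c1cc(OC(=O)c2ccc(N)cc2)ccc1O` carries 4-aminophenyl in place of 2-methylphenyl on a carbonyl carbon. For the measured compounds named here, the single measured step (a step that the two limits leave unreadable from compound 1 to compound 2) offers no size to carry over, so no change beyond the scatter is expected in this assay and no direction can be favoured. An estimated step that the limit leaves unreadable from compound 2 to compound 3 is expected. Compound 3 is expected at 0.2 h within a range of 0.08 h to 0.6 h and may well return only a limit.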

Compound 3, half-life: < 0.25 h
Compound 3 gave a limit, no number (the forecaster's own chance of this, stated with the estimate: 65%); the middle value lies beyond the limit too.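

No step can be read between compound 1, compound 2 and compound 3 in this assay, because all three stop at one limit: the limit of < 0.25 h in this assay, at which 3 of the 3 values shown sit.

The compounds shown leave open whether 4-aminophenyl and 2-methylphenyl on a carbonyl carbon differ at all in this assay.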